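The source may hold more compounds than are shown below. What is called first, only, known or untested is meant among the compounds shown, and "the series" means these compounds.

Compound 1, `Cc1nccn1-c1cnc(NCc2c(F)ccc3c2CCO3)c2cn[nH]c(=O)c12`: 2.1
Compound 2, `O=C1c2ccccc2CN1c1cnc(NCc2c(F)ccc3c2CCO3)n2cnnc12`: 2.7
Compound 3, `Cc1ncccc1-c1cnc(NCc2c(F)ccc3c2CCO3)c2n[nH]c(=O)n12`: 2.5

All three were measured in a physicochemical assay for lipophilicity, using the shake flask method, in phosphate buffer, measured as octanol-water partition, with a stated time of 30 min, at pH 7.4; a higher number here means a more lipophilic compound, a lower number a more polar compound. Compound 1 gives 2.1, the lowest of the three numbers: compound 3 stands a step higher that is beyond the scatter, and compound 2 stands further above it, also beyond the scatter. Compound 4, `Cn1nccc1-c1cnc(NCc2c(F)ccc3c2CCO3)c2cn[nH]c(=O)c12`, has not yet been measured. It differs from compound 1 in a single place: 1-methyl-1H-pyrazol-5-yl in place of 2-methyl-1H-imidazol-1-yl on an aromatic carbon. The two compounds have the same atoms, joined differently. Within the data shown here, no pair of measured compounds shows this change on its own, so its size cannot be read from the numbers at hand. A small rise in this assay, roughly the size of the scatter, is expected, which means a step of a number 0.40 log units higher from compound 1 to compound 4 (beyond the scatter). Compound 4 is thus estimated at 2.5, with a range from 2.1 to 2.9.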

Compound 4, distribution coefficient: 2.6
Beside the measured number, compound 4's estimate is 0.10 log units below it; the range from low to high includes it.
By their numbers in this assay, from the lowest: compound 1; then compounds 3, 4 and 2 (each within the scatter of the next).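

In this assay, 1-methyl-1H-pyrazol-5-yl in place of 2-methyl-1H-imidazol-1-yl gives a number 0.50 log units higher from compound 1 to compound 4 (beyond the scatter) on an otherwise unchanged compound. Among these compounds, this is the first change here that can be read at a single place, and it shows that joining the same atoms differently at this aromatic carbon is enough to move the number. Nothing available explains the step. Still open, on these data alone, is how an amine or a carboxylic acid at this position would read, and whether the same exchange gives a similar step on another core.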